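This account rests on a few compounds, and the source may have more. Where it says the series, first, only, none or still open, it means among the compounds named here.

Compound 3 `C[C@@H](Oc1cc2oc(=O)n(CCC(=O)O)c2cc1Cl)c1cccnn1` gives 631 nM in an assay on HEK293 cells for inhibition of kynurenine 3-monooxygenase (Homo sapiens), read by LC-MS, with a stated time of 20 h (on this read-out lower numbers stand for stronger inhibition and higher numbers for weaker inhibition), the second highest of the three numbers shown. Compound 1 `C[C@@H](Oc1cc2oc(=O)n(CCC(=O)O)c2cc1Cl)c1ccc(F)cn1` gives 25.1 nM, and the step of a 25-fold higher number from compound 1 to compound 3 (1.40 log units; beyond the scatter) is large. Compound 2 `O=C(O)CCn1c(=O)oc2cc(OCC3CCC3)c(Cl)cc21` gives 1260 nM, and the step of a 2.0-fold lower number from compound 2 to compound 3 (0.30 log units; within the scatter) lies within the scatter. Compound 4 `CCOc1cc2oc(=O)n(CCC(=O)O)c2cc1Cl` carries hydrogen in place of pyridazin-3-yl on a saturated chain carbon bound to an oxygen on an aromatic ring and a saturated chain carbon. Both measured steps change the group bound to the oxygen on the aromatic ring: one aromatic ring exchanged for another moved the number far, while an aromatic ring exchanged for a saturated ring did not move it beyond the scatter. Removing the ring altogether is a larger change than either, so a weaker result is expected, with a step of a 4.0-fold higher number from compound 3 to compound 4 (0.60 log units; beyond the scatter). Compound 4 is therefore estimated at 2500 nM, between 800 nM and 8000 nM.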

Compound 4, half-maximal inhibitory concentration: 398 nM
Estimate against measurement, compound 4: 6.3-fold (0.80 log units) above; the whole stated range lies above it.
By their numbers in this assay, from the lowest: compound 1; then compounds 4, 3 and 2 (each within the scatter of the next, the first and the last beyond it).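

In this assay hydrogen in place of pyridazin-3-yl on this saturated chain carbon is a step within the scatter (a 1.6-fold lower number from compound 3 to compound 4 (0.20 log units; within the scatter)), so here this ring cannot be told apart from no ring at all. Hydrogen in place of 5-fluoropyridin-2-yl is a large step (a 16-fold higher number from compound 1 to compound 4 (1.20 log units; beyond the scatter)), and methyl in place of cyclobutyl is a modest one (a 3.2-fold lower number from compound 2 to compound 4 (0.50 log units; beyond the scatter)), so the group at this place can count in either direction. No evidence is at hand to explain these steps. The compounds shown leave open how pyridin-2-yl without the fluorine, or a phenyl ring, would read at this place.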